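A Phenyl Swap on Compound 3: Expected Efficacy of Compound 4

The compounds below may be only part of what the source reports. "The series", "measured", "known", "first", "only" and "open" are said of these compounds alone.

Of the compounds shown here, three sharing one core have been tested in a functional assay on HEK293 cells for agonist activity at D(4) dopamine receptor (Homo sapiens), read by FLIPR; a higher number here means a larger maximal response, a lower number a smaller maximal response. Compound 1 `N#Cc1cccc(C(=O)NCN2CCC(c3cccc[n+]3[O-])CC2)c1` carries a 3-cyanophenyl on the carbonyl carbon, and in this assay compound 1 gives 69%. Compound 2 `O=C(NCN1CCC(c2cccc[n+]2[O-])CC1)c1cnccc1Cl` carries a 4-chloropyridin-3-yl in that place, and compound 2 gives 44%. Compound 3 `O=C(NCN1CCC(c2cccc[n+]2[O-])CC1)c1ccc(F)c(Cl)c1` carries a 3-chloro-4-fluorophenyl, and compound 3 gives 67%. On these numbers compound 3 stands second highest of the three: the change a number 2 percentage points lower from compound 1 to compound 3 (within the scatter) is within the scatter, whereas a number 23 percentage points higher from compound 2 to compound 3 (beyond the scatter) is beyond it, as is a number 25 percentage points lower from compound 1 to compound 2 (beyond the scatter).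

Compound 4 `Cc1cc(C(=O)NCN2CCC(c3cccc[n+]3[O-])CC2)ccc1Cl` is not yet measured. It differs from compound 3 in one place: 4-chloro-3-methylphenyl in place of 3-chloro-4-fluorophenyl on a carbonyl carbon. Both groups are six-membered aromatic rings of carbon only, each with one chlorine, and neither has a hydrogen-bond donor or acceptor. The closest guide is the step from one such ring to another, a number 2 percentage points lower from compound 1 to compound 3 (within the scatter), which stayed within the scatter; the steps beyond the scatter, a number 25 percentage points lower from compound 1 to compound 2 (beyond the scatter) and a number 23 percentage points higher from compound 2 to compound 3 (beyond the scatter), each involved the 4-chloropyridin-3-yl and so speak less to this change. A step of no more than the scatter is therefore expected, a number 2 percentage points lower from compound 3 to compound 4 (within the scatter). Compound 4 is thus estimated to give 65% in this assay, with a likely range from 48% to 82%.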

Compound 4, largest response reached (reported as efficacy), in percent of the reference or control that the assay uses: 62%
Estimate against measurement, compound 4: 3 percentage points above, and the stated range covers the measured number.
By their numbers in this assay, from the lowest: compound 2; then compounds 4, 3 and 1 (each within the scatter of the next).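

In this assay, replacing 3-chloro-4-fluorophenyl with 4-chloro-3-methylphenyl on this carbonyl carbon gives a number 5 percentage points lower from compound 3 to compound 4 (within the scatter), and the comparison with the 3-cyanophenyl gives a number 7 percentage points lower from compound 1 to compound 4 (within the scatter), so these three carbon-only aromatic rings cannot be told apart by this read-out. The 4-chloropyridin-3-yl of compound 2 remains the one group that separates from the others, now also in the step of a number 18 percentage points higher from compound 2 to compound 4 (beyond the scatter), and this holds for the four compounds shown and no further. Nothing shown explains these numbers or says what the methyl and the fluorine each contribute to them.

The compounds shown leave open what happens when this carbonyl carbon carries something other than an aromatic ring, such as a cyclohexyl or a longer alkyl chain, and whether a phenyl bearing a carboxylic acid or an amine would stay with compound 1, compound 3 and compound 4 or fall towards compound 2. A plain pyridin-3-yl without the chlorine would help to show whether the separate position of compound 2 goes with the chlorine or with the ring itself.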